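Replacing the 3,4-dihydroxyphenyl group of compound 1

The source may hold more compounds than are shown below. What is called first, only, known or untested is meant among the compounds shown, and "the series" means these compounds.

Measured so far:
compound 1 `CCOC(=O)C1=C(Nc2ccccc2)S/C(=C\c2ccc(O)c(O)c2)C1=O` 5200 nM
compound 2 `CCOC(=O)C1=C(Nc2ccccc2)S/C(=C\c2ccc([N+](=O)[O-])c(O)c2)C1=O` 12700 nM
compound 3 `CCOC(=O)C1=C(Nc2ccccc2)S/C(=C\c2ccc(C(=O)OCC)[nH]2)C1=O` 46800 nM

In a functional assay on K562 cells (Homo sapiens) for inhibition, read by MTT assay, with a stated time of 72 h (on this read-out higher numbers stand for weaker inhibition and lower numbers for stronger inhibition), compound 1 gives the lowest number of the three, with compound 2 next and compound 3 furthest away. Compound 4 `CCOC(=O)C1=C(Nc2ccccc2)S/C(=C\c2cc3ncccc3[nH]2)C1=O` differs from compound 1 by a group of 9 heavy atoms (7 carbon, 2 nitrogen; one five-membered aromatic ring with 1 hetero atom, one six-membered aromatic ring with 1 hetero atom) in place of a group of 8 heavy atoms (6 carbon, 2 oxygen; one six-membered aromatic ring of carbon only), on a double-bonded chain carbon bound to a double-bonded ring carbon. Among the measured compounds shown here, only one measured step touches this ring: a 2.4-fold higher number from compound 1 to compound 2 (0.39 log units; beyond the scatter) on exchanging a single substituent. For the measured compounds named here, compound 3, with a five-membered ring in place of the six-membered ring, stands far higher than compound 1, though no direct step between them is given. Both departures from compound 1 raised the number, so a larger rise than a 2.4-fold higher number from compound 1 to compound 2 (0.39 log units; beyond the scatter) is expected for compound 4, estimated as a 4.8-fold higher number from compound 1 to compound 4 (0.68 log units; beyond the scatter). Compound 4 is thus expected at 25000 nM, within 8000 nM to 80000 nM.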

Compound 4, half-maximal inhibitory concentration: 6600 nM
The estimate for compound 4 lay 3.8-fold (0.58 log units) above the measured number; measured number below the stated range.
By their numbers in this assay, from the lowest: compounds 1, 4 and 2 (each within the scatter of the next, the first and the last beyond it); then compound 3.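

The exchange on the double-bonded chain carbon gives a 1.3-fold higher number from compound 1 to compound 4 (0.10 log units; within the scatter) in this assay and so shows that this position can lose the 3,4-dihydroxyphenyl group without a change beyond the scatter. Among the compounds shown here, neither the carbon-only six-membered ring nor the two oxygens of that group are needed to keep the number in this range, which the earlier compounds did not show. No measured evidence bears on this result.

On these data alone, it remains open which of the two entering rings matters more for the number. Also open, as far as these compounds go, is how an amine or a carboxylic acid on the entering group would shift it.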